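Compound 3 to compound 4: hydrogen for the silicon-bearing group

This account rests on a few compounds, and the source may have more. Where it says the series, first, only, none or still open, it means among the compounds named here.

Measured in an ADME assay on DU-145 cells (Homo sapiens) for cytotoxicity, read by MTT assay, with a stated time of 72 h; on this read-out lower numbers stand for stronger inhibition and higher numbers for weaker inhibition:
- compound 1 `C=CCOc1cc(C2=C(c3cc(OC)c(OC)c(OC)c3)C(=O)C(O)C2)ccc1OC`: > 100 ug/mL (a limit)
- compound 2 `COc1ccc(C2=C(c3cc(OC)c(OC)c(OC)c3)C(=O)C(O)C2)cc1`: > 100 ug/mL (a limit)
- compound 3 `COc1ccc(C2=C(c3cc(OC)c(OC)c(OC)c3)C(=O)C(O[SiH2]C(C)(C)C)C2)cc1OC(C)C`: 6.3 ug/mL

Among the compounds with values here, compound 3, at 6.3 ug/mL, holds the only true number in this set. The other two values are limits of the assay. The next compound is compound 4 `COc1ccc(C2=C(c3cc(OC)c(OC)c(OC)c3)C(=O)C(O)C2)cc1OC(C)C`, not yet measured in this assay. The change from compound 3 is a hydrogen atom in place of a group of 5 heavy atoms (4 carbon, 1 silicon; no ring), on an oxygen on a saturated carbon.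

Within the data shown here, the one measured step, a step that the two limits leave unreadable from compound 1 to compound 2, is hydrogen in place of allyloxy on an aromatic carbon. It concerns a different place and offers no size to carry over. More relevant is the limit of > 100 ug/mL in this assay, at which 2 of the 3 values shown sit. Compound 4 carries the same hydrogen on that oxygen as compound 1. The value of compound 1, > 100 ug/mL, is a limit. Compound 2 also carries that hydrogen, and its > 100 ug/mL is likewise a limit. With only these compounds to go on, a large move toward weaker inhibition is expected in this assay, beyond the scatter. The expected change is a 16-fold higher number from compound 3 to compound 4 (1.20 log units; beyond the scatter). For compound 4 the estimate is 100 ug/mL, with an expected range of 35 ug/mL to 200 ug/mL.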

Compound 4, half-maximal inhibitory concentration: > 100 ug/mL
Compound 4: only a limit was reported; the forecaster's own chance of this, stated with the estimate: 60%; the middle value sits exactly at the limit.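

In this assay, within the data shown here, the hydrogen in place of the group of 5 heavy atoms on the oxygen on a saturated carbon is an at least 15-fold higher number from compound 3 to compound 4 (1.20 log units; beyond the scatter), the first step whose size can be read at all. Within the compounds shown, the single number therefore goes with the silicon-bearing group: with hydrogen on that oxygen, all three compounds sit at the limit, whichever of allyloxy, isopropoxy or hydrogen is on the aromatic carbon. The steps among compound 1, compound 2 and compound 4 cannot be read, since both ends of each are limits, and isopropoxy thus gains nothing visible over the other two: the limit of > 100 ug/mL in this assay, at which 3 of the 4 values shown sit.

Going by these compounds, it remains open whether silicon itself matters or whether a carbon-only group on that oxygen, such as a butyl chain or an acetyl ester, would give a measurable number as well. Compound 3 is the only compound shown with the silicon-bearing group, so it also remains open whether that group would give a number with allyloxy or hydrogen on the aromatic carbon in place of isopropoxy.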